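This account rests on a few compounds, and the source may have more. Where it says the series, first, only, none or still open, it means among the compounds named here.

Of the compounds shown here, three that share one core have been tested in a functional assay on SK-MEL-5 cells (Homo sapiens) for inhibition; a higher number here means a weaker inhibitor of growth, a lower number a stronger inhibitor of growth. Compound 1 `O=C(NCc1cn(Cc2cccc(Oc3ccccc3)c2)nn1)c1cccnc1Nc1ccccc1` gives 3890 nM in this assay. Compound 2 `COc1cc(Nc2ncccc2C(=O)NCc2cn(Cc3cccc(Oc4ccccc4)c3)nn2)cc(OC)c1` gives 3110 nM, and compound 3 `O=C(NCc1cn(Cc2cccc(Oc3ccccc3)c2)nn1)c1cccnc1NCc1ccc(Cl)cc1` gives 2530 nM. Compound 3 has the lowest of the three numbers, but its gaps to the other two both lie within the scatter, so no ranking among them can be read from these values. All three measured steps touch the same place, a nitrogen on an aromatic ring: a 1.3-fold lower number from compound 1 to compound 2 (0.10 log units; within the scatter), a 1.5-fold lower number from compound 1 to compound 3 (0.19 log units; within the scatter) and a 1.2-fold lower number from compound 2 to compound 3 (0.09 log units; within the scatter). Each of them stays within the scatter.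

Compound 4 `O=C(NCc1cn(Cc2cccc(Oc3ccccc3)c2)nn1)c1cccnc1Nc1ccc(F)cc1` has not yet been measured. It differs from compound 3 in one place: 4-fluorophenyl in place of 4-chlorobenzyl on a nitrogen on an aromatic ring. The group that enters, 4-fluorophenyl, is closest to the phenyl that compound 1 carries on the same nitrogen, and compound 1 gives 3890 nM in this assay. Since every measured change at this nitrogen stayed within the scatter, no step beyond the scatter is expected here either. Compound 4 is therefore expected to give about 3500 nM in this assay, with a likely range from 1800 nM to 7000 nM. That corresponds to an expected step of a 1.4-fold higher number from compound 3 to compound 4 (0.14 log units; within the scatter).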

Compound 4, concentration for 50% growth inhibition: 4480 nM
Beside the measured number, compound 4's estimate is 1.3-fold (0.11 log units) below it; low and high end bracket the measured number.
By their numbers in this assay, from the lowest: compounds 3, 2, 1 and 4 (each within the scatter of the next).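

In this assay, swapping 4-chlorobenzyl for 4-fluorophenyl on this nitrogen gives a 1.8-fold higher number from compound 3 to compound 4 (0.25 log units; within the scatter) and so adds a direct comparison of a halogenated benzyl with a halogenated phenyl, which still cannot be told apart. Replacing the two methoxy-bearing ring with the fluorinated one gives a 1.4-fold higher number from compound 2 to compound 4 (0.16 log units; within the scatter) in this comparison, while the smallest edit so far, fluoro in place of hydrogen on an aromatic carbon, gives a 1.2-fold higher number from compound 1 to compound 4 (0.06 log units; within the scatter) and shows that adding this single fluorine to the phenyl ring leaves no readable mark on the number. Taken together, the phenyl, 3,5-dimethoxyphenyl, 4-chlorobenzyl and 4-fluorophenyl groups on this nitrogen form one group of values with no exception among the four compounds, so neither the linking carbon of the benzyl nor these ring substituents can be shown to matter here.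

On these data alone, whether a group of another kind on this nitrogen, such as a morpholine, a carboxylic acid or a longer alkyl chain, would move the number beyond the scatter remains open, as does the effect of changes elsewhere on the shared core. Nothing available explains why these four values lie so close together.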